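Working notes: 4-hydroxyphenyl enters the series

This account rests on a few compounds, and the source may have more. Where it says the series, first, only, none or still open, it means among the compounds named here.

- compound 1 `COc1cccc(/C=C2\CCC/C(=C\c3cccc(Cl)c3)C2=O)c1OC` gives 10300 nM in a functional assay on HT-1080 cells (Homo sapiens) for cytotoxicity, read by MTT assay, with a stated time of 72 h; a lower number here means a stronger inhibitor, a higher number a weaker inhibitor
- compound 2 `COc1ccccc1/C=C1\CCC/C(=C\c2cccc(OC)c2OC)C1=O` gives 14100 nM in this assay

Only these two numbers exist so far. Going by the values given here, the single measured step is a 1.4-fold higher number from compound 1 to compound 2 (0.14 log units; within the scatter) and it sets no order between the two. Among the compounds with values here, compound 2 therefore stands within the scatter of the only other value available.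

The next structure is compound 3 `COc1cccc(/C=C2\CCC/C(=C\c3ccc(O)cc3)C2=O)c1OC` with 4-hydroxyphenyl in place of 2-methoxyphenyl on a double-bonded chain carbon bound to a double-bonded ring carbon and the rest of compound 2 unchanged. The measured step is the only one that bears on this place, and it involved neither a 4-hydroxyphenyl group nor any other group with a hydrogen-bond donor. Within the data shown here, the data hold no direct precedent for the incoming group, so the range must stay wide. Given a 1.4-fold higher number from compound 1 to compound 2 (0.14 log units; within the scatter) at this place, no step beyond the scatter is expected in this assay and no direction can be firmly assigned. The expected step is a 1.4-fold lower number from compound 2 to compound 3 (0.15 log units; within the scatter) and it is an estimate only. In this assay compound 3 is estimated at 10000 nM with 3500 nM to 25000 nM as the expected range.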

Compound 3, half-maximal inhibitory concentration: > 20000 nM
Compound 3: only a limit was reported; the forecaster's own chance of this, stated with the estimate: 5%; middle value at least 2.0-fold (0.30 log units) away from the limit.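

Compound 3 gives a limit and not a number in this assay: the limit of > 20000 nM in this assay, at which 1 of the 3 values shown sits.

At this place the series now runs to an at least 1.4-fold higher number from compound 2 to compound 3 (0.15 log units; that floor lies within the scatter), and to an at least 1.9-fold higher number from compound 1 to compound 3 (0.28 log units; that floor lies within the scatter), so both steps have a floor and no upper end, and neither can be placed beyond the scatter on what is printed. Going by these compounds alone, the earlier step between compound 1 and compound 2 had a measured size at both ends, whereas this change, which brings the first group here with 1 hydrogen-bond donor (4-hydroxyphenyl, in place of 2-methoxyphenyl with 0 hydrogen-bond donors), gives only that floor, so compound 3 cannot be ranked against either compound.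

The compounds shown do not separate the effect of the hydrogen-bond donor from that of the other differences between 4-hydroxyphenyl and 2-methoxyphenyl, and they give no reading for a 4-methoxyphenyl or a 4-aminophenyl group on a double-bonded chain carbon bound to a double-bonded ring carbon. On these data alone, how far the true value of compound 3 lies from the limit also stays open, as does whether any group at this place can give a number clearly apart from those of compound 1 and compound 2.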